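Working notes: an aryl swap on a carbonyl carbon

This account rests on a few compounds, and the source may have more. Where it says the series, first, only, none or still open, it means among the compounds named here.

In a functional assay on THP-1 cells (Homo sapiens) for inhibition (on this read-out lower numbers stand for stronger inhibition and higher numbers for weaker inhibition), compound 1 `O=C1C[C@H](NC(=O)[C@@H]2CNC[C@@H]3CCCC[C@H](NC(=O)c4ccccc4)C(=O)N32)C(O)O1` gives 245 nM and compound 2 `O=C1C[C@H](NC(=O)[C@@H]2COC[C@@H]3C/C=C\C[C@H](NC(=O)c4cccc(Cl)c4)C(=O)N32)C(O)O1` gives 118 nM as the lower of the two numbers, a gap beyond the scatter, although the two compounds differ in more than one place. Compound 3 `O=C1C[C@H](NC(=O)[C@@H]2COC[C@@H]3C/C=C\C[C@H](NC(=O)c4ccc5ccccc5c4)C(=O)N32)C(O)O1` carries naphthalen-2-yl in place of 3-chlorophenyl on a carbonyl carbon with naphthalen-2-yl in place of 3-chlorophenyl on a carbonyl carbon. For the measured compounds named here, no measured step covers this change. An estimate of a 1.1-fold lower number from compound 2 to compound 3 (0.03 log units; within the scatter) is expected here, with no shift beyond the scatter in this assay and no direction favoured. For compound 3 the expected value is 110 nM with an estimated range from 40 nM to 300 nM as the likely span.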

Compound 3, half-maximal inhibitory concentration: 62 nM
For compound 3 the middle estimate is 1.8-fold (0.25 log units) above the measured one; the measured number falls inside the stated range.
By their numbers in this assay, from the lowest: compounds 3 and 2 (each within the scatter of the next); then compound 1.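

In this assay, naphthalen-2-yl in place of 3-chlorophenyl on a carbonyl carbon gives a 1.9-fold lower number from compound 2 to compound 3 (0.28 log units; within the scatter), so this position takes either aryl group with no shift beyond the scatter. For the compounds shown here, this is the first single-place comparison, as compound 1 and compound 2 differ in more than one place. Going by these compounds, whether cyclohexyl or a phenyl carrying a carboxylic acid is tolerated on this carbonyl carbon stays open, as does the separate contribution of each place in which compound 1 and compound 2 differ. No measured evidence accompanies this step.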